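This account rests on a few compounds, and the source may have more. Where it says the series, first, only, none or still open, it means among the compounds named here.

In a functional assay on DU-145 cells (Homo sapiens) for inhibition, read by trypan blue exclusion, with a stated time of 96 h (on this read-out lower numbers stand for stronger inhibition of growth and higher numbers for weaker inhibition of growth), compound 1 (`COc1cc(OC)c(/C=C(/SCc2ccc(Cl)c(Cl)c2)C(=O)c2ccc(Cl)cc2)c(OC)c1`) gives 10000 nM and compound 2 (`COc1cc(OC)c(/C=C(/SCc2ccc(Cl)cc2Cl)C(=O)c2ccc(Cl)cc2)c(OC)c1`) gives 1000 nM, while compound 3 (`COc1cc(OC)c(/C=C(/SCc2ccc(F)cc2)C(=O)c2ccc(Cl)cc2)c(OC)c1`) gives 10000 nM and so stands level with compound 1, together the highest of the three numbers. Compound 4 (`COc1cc(OC)c(/C=C(\C(=O)c2ccc(Cl)cc2)S(=O)(=O)Cc2ccc(F)cc2)c(OC)c1`) carries (4-fluorobenzyl)sulfonyl in place of (4-fluorobenzyl)sulfanyl ((4-fluorobenzyl)sulfonyl in place of (4-fluorobenzyl)sulfanyl on a double-bonded chain carbon bound to a carbonyl carbon and a double-bonded chain carbon) on a double-bonded chain carbon bound to a carbonyl carbon and a double-bonded chain carbon. For the measured compounds named here, no measured step makes this change. The measured steps alter only the group on the saturated chain carbon bound to a sulfur, and they give only a rough guide to size: no change at the digits printed from compound 1 to compound 3 (within the scatter) and a 10-fold higher number from compound 2 to compound 3 (1.00 log units; beyond the scatter) on that group. A modest drop is expected, a 6.7-fold lower number from compound 3 to compound 4 (0.82 log units; beyond the scatter) as the estimate, though nothing measured fixes its direction. For compound 4 the estimated value is 1500 nM (range 150 nM to 10000 nM).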

Compound 4, concentration for 50% growth inhibition: 25000 nM
Compound 4: middle estimate off by 17-fold (1.22 log units), on the low side, and the stated range ends below it.
By their numbers in this assay, from the lowest: compound 2; then compounds 1 and 3 (each within the scatter of the next); then compound 4.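

In this assay, changing (4-fluorobenzyl)sulfanyl to (4-fluorobenzyl)sulfonyl at this position, with the benzyl part kept, gives a 2.5-fold higher number from compound 3 to compound 4 (0.40 log units; beyond the scatter), so adding oxygens to the sulfur weakens growth inhibition here. The sulfonyl compound also falls behind both dichlorobenzyl sulfanyl compounds, with a 2.5-fold higher number from compound 1 to compound 4 (0.40 log units; beyond the scatter) and, the widest gap, a 25-fold higher number from compound 2 to compound 4 (1.40 log units; beyond the scatter). Nothing available explains this loss.
The compounds shown leave open whether (2,4-dichlorobenzyl)sulfonyl would keep the stronger inhibition of compound 2, and how a sulfinyl group or an amine would read at this position.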